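Pyrazole substituent removal in a glucagon receptor antagonist series

A few compounds are considered here, and "the series" means these few. Any claim that something is new, unique, unknown or untested is made for them only; others in the source may bear on it.

Measured compounds:
compound 1, `CCCC(Nc1ccc(-n2cc(C(F)(F)F)cn2)nc1)c1ccc(C(=O)NCCC(=O)O)cc1`, 170 nM
compound 2, `CCCC(Oc1ccc(-n2cc(C(=O)N(C)C)cn2)cc1)c1ccc(C(=O)NCCC(=O)O)cc1`, 6500 nM
compound 3, `O=C(O)CCNC(=O)c1ccc(C(Oc2ccc(-n3cc(C(F)(F)F)cn3)cc2)C2CCCC2)cc1`, 420 nM

In an assay on cells for displacement of a labelled ligand from Glucagon receptor (Homo sapiens), in the presence of a further agent that is not named here (on this read-out higher numbers stand for weaker inhibition and lower numbers for stronger inhibition), compound 1 gives 170 nM and compound 3 gives 420 nM, while compound 2 gives 6500 nM. Compound 2 therefore stands at the highest number of the three; its gaps to compound 3 and to compound 1 both lie beyond the scatter, so it is the weakest inhibitor among these. Compound 1 and compound 3 carry trifluoromethyl on the pyrazole, compound 2 carries dimethylcarbamoyl there.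

Compound 4 `CCCC(Oc1ccc(-n2cccn2)cc1)c1ccc(C(=O)NCCC(=O)O)cc1` is not yet measured. It differs from compound 2 by hydrogen in place of dimethylcarbamoyl on an aromatic carbon. Among the measured compounds shown here, no measured pair shows this change, so its size is not known from the data. Since compound 2 with 6500 nM lies far above the trifluoromethyl analogues, a move toward lower numbers is expected for the bare pyrazole, but of uncertain size. For compound 4 the step of a 3.3-fold lower number from compound 2 to compound 4 (0.51 log units; beyond the scatter) is expected, likely beyond the scatter. Compound 4 is estimated at 2000 nM, within 500 nM to 8000 nM.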

Compound 4, inhibition constant: 4100 nM
Compound 4: middle estimate off by 2.1-fold (0.31 log units), on the low side; low and high end bracket the measured number.
By their numbers in this assay, from the lowest: compound 1; then compound 3; then compounds 4 and 2 (each within the scatter of the next).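

In this assay, among the compounds shown here, hydrogen in place of dimethylcarbamoyl on the pyrazole gives a 1.6-fold lower number from compound 2 to compound 4 (0.20 log units; within the scatter), the first single-place comparison at this position. On this read-out, the 4-(dimethylcarbamoyl)-1H-pyrazol-1-yl and 1H-pyrazol-1-yl forms cannot be told apart, so this pair gives no sign that the dimethylcarbamoyl group on its own sets the number of compound 2. No supporting measurement bears on why these two compounds read alike.

From the compounds shown here alone, it remains open how a methyl group, a nitrile or trifluoromethyl would read on this same pyrazole carbon with the rest of compound 4 unchanged. Compound 1 and compound 3 carry trifluoromethyl but also differ from compound 4 elsewhere, so they do not isolate the contribution of that group.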